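Shortening the alkynyl ether chain to a butenyl chain

The source may hold more compounds than are shown below. What is called first, only, known or untested is meant among the compounds shown, and "the series" means these compounds.

- compound 1 `C=CCCCCOc1ccccc1-c1cnc(OCCC=C)n1C`: 29000 nM
- compound 2 `CCCCOc1ncc(-c2ccccc2OC)n1C`: 96000 nM
- compound 3 `C#CCCCCOc1ncc(-c2ccccc2OC)n1C`: 35000 nM
- compound 4 `C=CCCOc1ncc(-c2ccccc2OC)n1C`: not yet measured

Compound 3 lies within the scatter of compound 1 and beyond the scatter on the lower side of compound 2. The move to compound 4 is vinyl in place of but-3-yn-1-yl on a saturated chain carbon, two bonds along the chain from an oxygen on an aromatic ring. Going by the values given here, one measured step bears on it: a 2.7-fold lower number from compound 2 to compound 3 (0.44 log units; beyond the scatter), which introduced the ethynyl group. Among the compounds with values here, no measured step covers a vinyl group. Compound 4 stands structurally nearer compound 2, so most of that step is expected to reverse. The expected step in a functional assay on T98G cells (Homo sapiens) for inhibition, read by colorimetric assay and MTT assay, with a stated time of 72 h (on this read-out higher numbers stand for weaker inhibition and lower numbers for stronger inhibition), is a 2.1-fold higher number from compound 3 to compound 4 (0.33 log units; beyond the scatter), a modest move to a higher number. Compound 4 is estimated at 75000 nM, within a range of 40000 nM to 130000 nM.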

Compound 4, half-maximal inhibitory concentration: 39000 nM
Compound 4: the middle estimate sits 1.9-fold (0.28 log units) above what was measured; the measured number lies below the stated range.
By their numbers in this assay, from the lowest: compounds 1, 3 and 4 (each within the scatter of the next); then compound 2.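

In this assay, the shorter but-3-en-1-yl ether holds the level of the hex-5-yn-1-yl ether, with a 1.1-fold higher number from compound 3 to compound 4 (0.05 log units; within the scatter). Chain length alone does not set the number, since vinyl in place of ethyl at the same chain carbon gives a 2.5-fold lower number from compound 2 to compound 4 (0.39 log units; beyond the scatter). Hydrogen in place of pent-4-en-1-yl on the saturated chain carbon bound to an oxygen on an aromatic ring stays within the scatter, with a 1.3-fold higher number from compound 1 to compound 4 (0.13 log units; within the scatter).

Open, as far as these compounds go, is whether a chain ending in an amine or a carboxylic acid departs from this level. Nothing measured here gives a reason for these steps.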